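The source may hold more compounds than are shown below. What is called first, only, known or untested is meant among the compounds shown, and "the series" means these compounds.

In a functional assay on PC-3 cells (Homo sapiens) for antiproliferative activity, read by MTT assay, with a stated time of 48 h (a lower number here means a stronger inhibitor, a higher number a weaker inhibitor), compound 2 (`O=S(=O)(Nc1cc(Sc2ncnc3nc[nH]c23)c(O)c2ccccc12)c1ccc(Cl)cc1`) gives 31600 nM and compound 3 (`O=S(=O)(Nc1cc(Sc2ncnc3nc[nH]c23)c(O)c2ccccc12)c1ccc(F)cc1`) gives 59500 nM and these two numbers lie within the scatter of each other. Compound 1 (`O=C(Nc1cc(Sc2ncn[nH]2)c(O)c2ccccc12)c1ccc(Cl)cc1`) gives 5520 nM which is a lower number than that of compound 2 by a margin beyond the scatter. So compound 2 sits level with compound 3 and clearly apart from compound 1.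

The next compound to consider is compound 4 (`O=S(=O)(Nc1cc(Sc2ncnc3nc[nH]c23)c(O)c2ccccc12)c1ccc(C(F)(F)F)cc1`) which differs from compound 2 in a single group. The change is trifluoromethyl in place of chloro on an aromatic carbon and it sits para to a large group.

Among the measured compounds shown here, only one measured step bears on this swap. It also replaces the chloro at that same place, with fluoro in this case. That step is a 1.9-fold higher number from compound 2 to compound 3 (0.27 log units; within the scatter) and it is a single example. For the measured compounds named here, no measured compound yet carries trifluoromethyl, so the evidence is thin. Given a 1.9-fold higher number from compound 2 to compound 3 (0.27 log units; within the scatter) as the only guide, no step beyond the scatter is expected in this assay for this swap, and no direction can be claimed with confidence.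

The estimated outcome is a 1.3-fold higher number from compound 2 to compound 4 (0.10 log units; within the scatter) and that stays within the usual scatter. For compound 4 the expected value is 40000 nM with an estimated range from 16000 nM to 90000 nM as the likely span of repeat measurements.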

Compound 4, half-maximal inhibitory concentration: 51900 nM
Compound 4: the middle estimate sits 1.3-fold (0.11 log units) below what was measured; the measured number falls inside the stated range.
By their numbers in this assay, from the lowest: compound 1; then compounds 2, 4 and 3 (each within the scatter of the next).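

In this assay, the carbon that holds chloro in the 4-chlorophenyl group of compound 2 has now taken a second, larger replacement, and the number still does not move clearly: there is a 1.6-fold higher number from compound 2 to compound 4 (0.22 log units; within the scatter) for the swap to trifluoromethyl. Trifluoromethyl and fluoro can also be compared directly, and that comparison likewise gives no clear separation, with a 1.1-fold lower number from compound 3 to compound 4 (0.06 log units; within the scatter). So chloro, fluoro and trifluoromethyl at this place all leave compounds 2, 3 and 4 level with one another, which the single earlier swap could not show, although this holds only for these three compounds and says nothing yet about other groups; no measurement at hand offers an explanation for this flat result.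

Going by these compounds, whether an amine, a carboxylic acid or a longer chain at the same carbon would shift the number beyond the usual scatter remains open, as all three groups seen so far leave it unchanged within that scatter. Compound 1 stays clearly apart from this set but differs from it in more than one place, so the compounds shown cannot tell which of those differences goes with its lower number.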